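The compounds below may be only part of what the source reports. "The series", "measured", "known", "first", "only" and "open" are said of these compounds alone.

Measured so far in a functional assay on PC-3 cells (Homo sapiens) for inhibition, read by MTT assay, with a stated time of 24 h; on this read-out lower numbers stand for stronger inhibition and higher numbers for weaker inhibition:
Compound 1 `COc1ccc(-n2cc(/C=[N+](\[O-])Cc3ccccc3)nn2)cc1` gives > 100000 nM, a limit of the assay.
Compound 2 `[O-]/[N+](=C\c1cn(CCC(F)(F)C(F)(F)C(F)(F)C(F)(F)C(F)(F)C(F)(F)F)nn1)Cc1ccccc1` gives > 100000 nM, also a limit of the assay.
Compound 3 `COc1ccc(-n2cc(/C=[N+](\[O-])C(C)(C)C)nn2)cc1` gives 23800 nM.

Compound 3 differs from compound 1 by tert-butyl in place of benzyl on a double-bonded nitrogen. The step is an at least 4.2-fold lower number from compound 1 to compound 3 (0.62 log units; beyond the scatter); its true size is open at the upper end because of the limit of > 100000 nM in this assay, at which 2 of the 3 values shown sit.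

Compound 2 and compound 1 carry different cores; the difference between the two cores is not broken down here. Compound 4 `CC(C)(C)/[N+]([O-])=C/c1cn(CCC(F)(F)C(F)(F)C(F)(F)C(F)(F)C(F)(F)C(F)(F)F)nn1` is not yet measured and differs from compound 2 by tert-butyl in place of benzyl on a double-bonded nitrogen, the same change as from compound 1 to compound 3.

For compound 2 only a limit is known in this assay, so the step to compound 4 cannot be anchored. The expectation rests on compound 1 and compound 3 an at least 4.2-fold lower number from compound 1 to compound 3 (0.62 log units; beyond the scatter) and is a step of an at least 2.0-fold lower number from compound 2 to compound 4 (0.30 log units; that floor lies within the scatter) from compound 2 to compound 4. Compound 4 is thus estimated at 50000 nM, within a band from 15000 nM to 150000 nM, with a real chance that this assay again reports only a limit.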

Compound 4, half-maximal inhibitory concentration: 11200 nM
Estimate against measurement, compound 4: 4.5-fold (0.65 log units) above; the whole stated range lies above it.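

In this assay, tert-butyl in place of benzyl on a double-bonded nitrogen gives an at least 8.9-fold lower number from compound 2 to compound 4 (0.95 log units; beyond the scatter), so the direction of the change carries over from the core of compound 1 to the core of compound 2, with no compound shown going against it. This does not fix the size of either step, and the values for the benzyl compounds are limits, not numbers: the limit of > 100000 nM in this assay, at which 2 of the 4 values shown sit. Nor does it show that the change carries over with the same size on both cores: the same change on two cores in this assay, an at least 4.2-fold lower number (0.62 log units; beyond the scatter) from compound 1 to compound 3 and an at least 8.9-fold lower number (0.95 log units; beyond the scatter) from compound 2 to compound 4; the limit leaves it open whether they differ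

Two cores cannot show whether the change holds on a third, and the compounds shown leave open how the number moves with other groups on that nitrogen, such as isopropyl or cyclohexyl. Going by these compounds, it also remains open whether an amine or a carboxylic acid on the chain of compound 4 would keep a measurable number in this assay.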